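This account rests on a few compounds, and the source may have more. Where it says the series, first, only, none or still open, it means among the compounds named here.

Three compounds were measured in a functional assay on MDA-MB-231 cells (Homo sapiens) for cytotoxicity, read by MTT assay, with a stated time of 48 h; on this read-out higher numbers stand for weaker inhibition and lower numbers for stronger inhibition:

Compound 1, `O=C(/C=C/c1ccc2c(c1)B(O)OC2)c1ccc(O)cc1`, gives 25600 nM.
Compound 2, `Nc1ccc(C(=O)/C=C/c2ccc3c(c2)B(O)OC3)cc1`, gives 25800 nM.
Compound 3, `O=C(/C=C/c1ccc2c(c1)B(O)OC2)c1cccc(O)c1`, gives 2700 nM.

Compound 1 and compound 3 share the same atoms joined differently; their cores differ by 3-hydroxyphenyl in place of 4-hydroxyphenyl on a carbonyl carbon, and this rearrangement brings a 9.5-fold lower number from compound 1 to compound 3 (0.98 log units; beyond the scatter), leaving compound 3 as the lowest number of the three. Compound 1 and compound 2 differ by amino in place of hydroxy on an aromatic carbon, which gives a 1.0-fold higher number from compound 1 to compound 2 (0.00 log units; within the scatter).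

Compound 4, `Nc1cccc(C(=O)/C=C/c2ccc3c(c2)B(O)OC3)c1`, has not been measured. It differs from compound 3 by amino in place of hydroxy on an aromatic carbon. This is the same kind of change as that from compound 1 to compound 2, though not the same: there the amino sits para to a large group, here it sits meta to a large group. Going by the values given here, on the single precedent of compound 1 to compound 2, a 1.0-fold higher number from compound 1 to compound 2 (0.00 log units; within the scatter), the exchange is expected to change little, so compound 4 is expected to show a 1.0-fold higher number from compound 3 to compound 4 (0.02 log units; within the scatter) relative to compound 3. Compound 4 is therefore estimated at 2800 nM in this assay, with a likely range from 1200 nM to 7000 nM.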

Compound 4, half-maximal inhibitory concentration: 3200 nM
Compound 4: middle estimate off by 1.1-fold (0.06 log units), on the low side; measured number inside the range.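

In this assay, amino in place of hydroxy gives a 1.2-fold higher number from compound 3 to compound 4 (0.07 log units; within the scatter), and the same exchange on two cores gives steps that do not differ: the same change on two cores in this assay, a 1.0-fold higher number (0.00 log units; within the scatter) from compound 1 to compound 2 and a 1.2-fold higher number (0.07 log units; within the scatter) from compound 3 to compound 4, 1.2-fold (0.07 log units) apart, within the scatter of two such steps The larger steps come with the change of ring substitution, since 3-aminophenyl in place of 4-aminophenyl gives an 8.1-fold lower number from compound 2 to compound 4 (0.91 log units; beyond the scatter) and 3-aminophenyl in place of 4-hydroxyphenyl gives an 8.0-fold lower number from compound 1 to compound 4 (0.90 log units; beyond the scatter). The exchange of hydroxy for amino therefore carried over between these two cores in this assay, but two pairs do not show that it would carry over to a core beyond those shown, and they do not explain why the exchange leaves the number within the scatter.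

Going by these compounds, whether a methoxy, a dimethylamino or a carboxylic acid in the place of the hydroxy would behave like the amino remains open. So does whether the match between the two pairs would hold on other cell lines.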